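A few compounds are considered here, and "the series" means these few. Any claim that something is new, unique, unknown or untested is made for them only; others in the source may bear on it.

The three measured compounds share one core and differ only in what sits on the aromatic carbon para to a large group. In a functional assay on HUVEC cells (Homo sapiens), read by fluorescence and microscopy, with a stated time of 6 h, tested at 10 uM (on this read-out higher numbers stand for a weaker effect at the one concentration tested and lower numbers for a stronger effect), compound 1 `N#Cc1c(Nc2ccc([N+](=O)[O-])cc2)sc2ccccc12` gives 8%. In this assay compound 2 `N#Cc1c(Nc2ccc(Cl)cc2)sc2ccccc12` gives 45%, and compound 3 `N#Cc1c(Nc2ccccc2)sc2ccccc12` gives 81%. Compound 3 therefore stands highest of the three numbers, with a number 36 percentage points higher from compound 2 to compound 3 (beyond the scatter) separating it from its nearest neighbour and a number 73 percentage points higher from compound 1 to compound 3 (beyond the scatter) from the furthest.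

Compound 4 `N#Cc1c(Nc2ccc(O)cc2)sc2ccccc12` differs from compound 3 by hydroxy in place of hydrogen on an aromatic carbon. For the measured compounds named here, the steps that bear on this are a number 36 percentage points higher from compound 2 to compound 3 (beyond the scatter) and a number 73 percentage points higher from compound 1 to compound 3 (beyond the scatter), both large, and in both a group at that place gave way to hydrogen and the number rose. Going by the values given here, compound 4 runs the other way, a group entering where hydrogen was, and no measured compound carries a hydroxy there, so the size is uncertain. A downward step is nonetheless expected, a number 21 percentage points lower from compound 3 to compound 4 (beyond the scatter). Compound 4 is estimated at 60%, within a range from 35% to 90%.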

Compound 4, a percentage reported as activity, at one concentration (the size of the read-out at that concentration, not a potency): 25%
Compound 4: middle estimate off by 35 percentage points, on the high side; the whole stated range lies above it.
By their numbers in this assay, from the lowest: compound 1; then compound 4; then compound 2; then compound 3.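

In this assay, hydroxy at this place also pulls the number down from that of the unsubstituted compound 3 (a number 56 percentage points lower from compound 3 to compound 4 (beyond the scatter)), so the drop seen with nitro and chloro is not confined to those two groups. Hydroxy does not fall in line behind either of them but lands between them, on one side lower than chloro (a number 20 percentage points lower from compound 2 to compound 4 (beyond the scatter)) and on the other higher than nitro (a number 17 percentage points higher from compound 1 to compound 4 (beyond the scatter)), giving an order of nitro, hydroxy, chloro and hydrogen from the lowest number to the highest. Nothing available explains this order.

From the compounds shown here alone, whether an amine, a methoxy or a carboxylic acid at this place would also lower the number remains open. So does how these four compounds would compare at any other concentration.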